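A few compounds are considered here, and "the series" means these few. Any claim that something is new, unique, unknown or untested is made for them only; others in the source may bear on it.

In an assay on CHO-K1 cells for displacement of a labelled ligand from prostaglandin E2 receptor EP1 subtype (Homo sapiens) (a lower number here means a stronger inhibitor, a higher number a weaker inhibitor), compound 1 `Cc1cc(C(N)=O)nn1Cc1cc(Cl)ccc1OCc1ccccc1` gives 126 nM, and compound 2 `CNC(=O)c1cc(C)n(Cc2cc(Cl)ccc2OCc2ccccc2)n1` gives 100 nM. The difference is a 1.3-fold lower number from compound 1 to compound 2 (0.10 log units; within the scatter), a change that left the number essentially where it was. Compound 2 therefore stands alongside compound 1, the two numbers within the scatter of each other. Compound 3 `Cc1cc(C(=O)NC(C)C)nn1Cc1cc(Cl)ccc1OCc1ccccc1` carries the same nitrogen one step further: isopropyl in place of methyl on an amide-type nitrogen. Within the data shown here, only that one earlier step bears on this change, and it moved nothing beyond the scatter, so the expected step is a 1.2-fold higher number from compound 2 to compound 3 (0.08 log units; within the scatter), again nothing beyond the scatter. For compound 3 the estimate is 120 nM, in a range from 45 nM to 320 nM.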

Compound 3, half-maximal inhibitory concentration: 126 nM
The estimate for compound 3 lay 1.1-fold (0.02 log units) below the measured number; measured number inside the range.
By their numbers in this assay, from the lowest: compounds 2, 1 and 3 (each within the scatter of the next).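

Three sizes of group now sit on the amide-type nitrogen in this assay, and the number has not responded to any of them. Methyl to isopropyl gives a 1.3-fold higher number from compound 2 to compound 3 (0.10 log units; within the scatter), and hydrogen to isopropyl gives no change at the digits printed from compound 1 to compound 3 (within the scatter), so the larger branched group is accepted here as readily as the smaller ones. Nothing available explains why this change leaves the number in place.

As far as these compounds go, whether that holds for a longer chain, a phenyl ring or a chain ending in an amine or a carboxylic acid on this nitrogen remains open.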